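A few compounds are considered here, and "the series" means these few. Any claim that something is new, unique, unknown or untested is made for them only; others in the source may bear on it.

Of the compounds shown here, three that share one core have been read so far in a physicochemical assay for solubility, read by turbidimetry, measured as kinetic solubility, at pH 6.8; a lower number here means a less soluble compound, a higher number a more soluble compound. In this assay, compound 1 `COc1ccccc1N1C(=O)CSC1c1cc(F)cc(C(=O)NCCCCc2ccccc2)c1` gives 10000 nM, compound 2 `Cc1cccc(N2C(=O)CSC2c2cccc(C(=O)NCCCCc3ccccc3)c2)c1` gives 10000 nM, and compound 3 `C#Cc1cccc(N2C(=O)CSC2c2cccc(C(=O)NCCCCc3ccccc3)c2)c1` gives 10000 nM. Among the measured compounds shown here, compound 3 therefore stands level with the other two, and the numbers so far separate none of them.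

The next compound, compound 4 `CC(F)(F)c1cccc(N2C(=O)CSC2c2cccc(C(=O)NCCCCc3ccccc3)c2)c1`, changes a single group of compound 3: 1,1-difluoroethyl in place of ethynyl on an aromatic carbon. In plain words, 1,1-difluoroethyl takes the place of ethynyl on an aromatic carbon, meta to a large group.

For the measured compounds named here, only one measured step swaps one group for another at this place: no change at the digits printed from compound 2 to compound 3 (within the scatter), with ethynyl in place of methyl. That step stays within the scatter. Going by the values given here, no measured compound carries 1,1-difluoroethyl, so the data say nothing directly about this group, and one step is thin evidence. With that caution, the expectation rests on compound 3 at 10000 nM and on the flat step no change at the digits printed from compound 2 to compound 3 (within the scatter), so no move beyond the scatter is expected in either direction in this assay. The estimated step is no change at the digits printed from compound 3 to compound 4 (within the scatter). For compound 4 the estimated value is 10000 nM, with an expected range from 5000 nM to 20000 nM.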

Compound 4, solubility: 10000 nM
For compound 4 middle estimate and measured number coincide at the digits printed; the measured number falls inside the stated range.
By their numbers in this assay, from the lowest: compounds 1, 2, 3 and 4 (each within the scatter of the next).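

In this assay, this place on the aromatic ring, meta to a large group, has now held a third group, and the reading shows no change at the digits printed from compound 3 to compound 4 (within the scatter). The comparison with the methyl compound gives the same picture, with no change at the digits printed from compound 2 to compound 4 (within the scatter), so methyl, ethynyl and 1,1-difluoroethyl all read alike at this place, even though 1,1-difluoroethyl brings 4 heavy atoms, 2 of them fluorine, where ethynyl has 2 heavy atoms, both carbon. No measurement at hand explains this flat reading.

As far as these compounds go, all three groups at this place carry no hydrogen-bond donors and no net charge, so it remains open whether an amine or a carboxylic acid there would also leave the number unmoved. Also open, from the compounds shown here alone, is whether a change elsewhere on the shared core, such as a longer chain on the amide, would shift the reading when the group at this place stays the same.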